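The source may hold more compounds than are shown below. What is called first, only, known or untested is meant among the compounds shown, and "the series" means these compounds.

Measured so far in a functional assay on MDA-MB-231 cells (Homo sapiens) for inhibition, read by sulforhodamine B assay, with a stated time of 72 h; on this read-out higher numbers stand for weaker inhibition of growth and lower numbers for stronger inhibition of growth:
compound 1, `NC(=O)/C=C/c1ccncc1-c1ccc2ccccc2c1` — > 10000 nM
compound 2, `CN1CCN(C(=O)/C=C/c2ccncc2-c2ccc3ccccc3c2)CC1` — > 10000 nM
compound 3, `CN(C)C(=O)/C=C/c1ccncc1-c1ccc2ccccc2c1` — 7990 nM

The values given for compound 1 and for compound 2 are each a limit of the assay, not a number, so the limit of > 10000 nM in this assay, at which 2 of the 3 values shown sit, is where two of the three results sit. Among the measured compounds shown here, compound 3 holds the only actual number. The steps to it, an at least 1.2-fold lower number from compound 1 to compound 3 (0.09 log units; that floor lies within the scatter) and an at least 1.2-fold lower number from compound 2 to compound 3 (0.09 log units; that floor lies within the scatter), have floors that lie within the scatter, so no clear movement is visible among the three. Compound 4, `CCOC(=O)/C=C/c1ccncc1-c1ccc2ccccc2c1`, differs from compound 3 by ethoxy in place of dimethylamino on a carbonyl carbon. For the measured compounds named here, no measured step involves ethoxy, and the known steps are small, so compound 4 is expected to show a 1.0-fold higher number from compound 3 to compound 4 (0.00 log units; within the scatter), with an estimated value of 8000 nM in a range from 2500 nM to 25000 nM.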

Compound 4, concentration for 50% growth inhibition: 8090 nM
Compound 4: the middle estimate sits 1.0-fold (0.00 log units) below what was measured; the measured number falls inside the stated range.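

In this assay, ethoxy in place of dimethylamino gives a 1.0-fold higher number from compound 3 to compound 4 (0.01 log units; within the scatter), so a readable number at this carbonyl carbon does not depend on a nitrogen attached there. The steps from the two compounds held at the assay limit are an at least 1.2-fold lower number from compound 2 to compound 4 (0.09 log units; that floor lies within the scatter) and an at least 1.2-fold lower number from compound 1 to compound 4 (0.09 log units; that floor lies within the scatter), so they show no clear gain either. What the compounds shown leave open is whether a carboxylic acid, or a longer chain in place of ethoxy, would move the number beyond the scatter.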